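Arylpiperazine phthalimidobutyl series: aryl swap toward 4-acetamidophenyl

This account rests on a few compounds, and the source may have more. Where it says the series, first, only, none or still open, it means among the compounds named here.

Two compounds of the shared core carry a measured number in an assay on frontal cortex for binding affinity to Adrenergic receptor alpha-1 (Rattus norvegicus), read by radioligand binding; a higher number here means a weaker inhibitor, a lower number a stronger inhibitor. Compound 1 `COc1ccc(OC)c(N2CCN(CCCCN3C(=O)c4ccccc4C3=O)CC2)c1` gives 15 nM. Compound 2 `O=C1c2ccccc2C(=O)N1CCCCN1CCN(c2ccccc2[N+](=O)[O-])CC1` gives 25 nM. Compound 2 stands with the highest of the two numbers, and its nearest neighbour is compound 1, the gap being a 1.7-fold higher number from compound 1 to compound 2 (0.22 log units; within the scatter), so the two cannot be ordered on these data.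

The next compound, compound 3 `CC(=O)Nc1ccc(N2CCN(CCCCN3C(=O)c4ccccc4C3=O)CC2)cc1`, differs from compound 2 in one place: 4-acetamidophenyl in place of 2-nitrophenyl on an amine nitrogen in a ring. Among the measured compounds shown here, the only measured step that bears on this is the exchange of one aryl group for another on the same amine nitrogen in a ring, the step from compound 1 to compound 2, which amounted to a 1.7-fold higher number from compound 1 to compound 2 (0.22 log units; within the scatter). For the measured compounds named here, that one step suggests the series tolerates a change of the aryl group without a shift beyond the scatter, but it covers only two aryl groups, neither of which carries a hydrogen-bond donor, so the step to compound 3 is only loosely anchored.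

For compound 3 in this assay a modest rise in the number is expected, a 2.0-fold higher number from compound 2 to compound 3 (0.30 log units; within the scatter), with the estimate 50 nM and a range from 12 nM to 200 nM.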

Compound 3, inhibition constant: < 1000 nM
Compound 3: no number, only a limit; the forecaster's own chance of this, stated with the estimate: 3%; the middle value lies beyond the limit too.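

In this assay compound 3 gives < 1000 nM, which is a limit and not a number, so the steps to compound 3 from compound 1 and compound 2 cannot be read: the limit of < 1000 nM in this assay, at which 1 of the 3 values shown sits.

The compounds shown leave open whether 4-acetamidophenyl in place of 2-nitrophenyl or 2,5-dimethoxyphenyl on the amine nitrogen shifts the number at all.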